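The compounds below may be only part of what the source reports. "The series", "measured", "known", "first", "only" and "open" are said of these compounds alone.

Three compounds have numbers in an assay on HEK293 cells for displacement of a labelled ligand from D(4) dopamine receptor (Homo sapiens), read by scintillation counting, with a stated time of 60 min (a lower number here means a stronger inhibitor, a higher number a weaker inhibitor), so far:

compound 1 `Cc1cccc(NC(=O)CN2CCC(c3ccc(Cl)cc3)CC2)c1` gives 115 nM
compound 2 `CCc1cccc(NC(=O)CN2CCN(c3ccccn3)CC2)c1` gives 67.9 nM
compound 3 `O=C(CN1CCN(c2ccccn2)CC1)Nc1cncnc1` gives 39300 nM

Compound 1 stands second highest of the three. Its nearest neighbour is compound 2, whose number is lower but within the scatter, so the two cannot be told apart. Among the measured compounds shown here, compound 3 is far away: the single recorded step, a 580-fold higher number from compound 2 to compound 3 (2.76 log units; beyond the scatter), shows how much is lost when pyrimidin-5-yl replaces 3-ethylphenyl on the amide-type nitrogen.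

Compound 4 `Cc1ccc(C2CCN(CC(=O)Nc3cccc(C)c3)CC2)nc1` differs from compound 1 in one place: 5-methylpyridin-2-yl in place of 4-chlorophenyl on a saturated ring carbon. The saturated ring carbon that carries this group is three ring bonds from the ring nitrogen. For the measured compounds named here, no measured step touches that side of the shared core; the only step on record concerns the amide-type nitrogen, and its size says nothing direct about the saturated ring carbon. Going by the values given here, the exchange of a carbon-only ring for a ring with 1 hetero atom at a distinct position therefore carries no precedent here, and nothing in the data points to a shift beyond the scatter in either direction.

Compound 4 is estimated at 180 nM, with a range of 50 nM to 650 nM. The expected step is a 1.6-fold higher number from compound 1 to compound 4 (0.19 log units; within the scatter).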

Compound 4, inhibition constant: 41.7 nM
Compound 4: middle estimate off by 4.3-fold (0.64 log units), on the high side, outside the stated range (below it).
By their numbers in this assay, from the lowest: compounds 4, 2 and 1 (each within the scatter of the next, the first and the last beyond it); then compound 3.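

In this assay, among the compounds shown here, the exchange on the saturated ring carbon gives a 2.8-fold lower number from compound 1 to compound 4 (0.44 log units; beyond the scatter), the first step on record on this side of the shared core, and it shows that the group held at this position affects the number, though modestly. The change also shows that the 4-chlorophenyl group is not needed for binding at this level, since 5-methylpyridin-2-yl, with the same count of 7 heavy atoms, one six-membered aromatic ring and 1 hydrogen-bond acceptor where the leaving group has none, gives a lower number, yet nothing shown explains this step. Several features change together in this one exchange, since chlorine leaves while a ring nitrogen and a methyl group enter, so the step belongs to the whole group and cannot be assigned to any single one of these features.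

The compounds shown leave open whether the ring nitrogen or the methyl group accounts for the step, a question that plain pyridin-2-yl or 4-methylphenyl on the same carbon would address. They also leave open how this position would respond to a group of another kind, such as a carboxylic acid or an amine on the ring.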